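Extending the Acid Chain of a Selenocyanate Anilide

This account rests on a few compounds, and the source may have more. Where it says the series, first, only, none or still open, it means among the compounds named here.

Three compounds sharing a selenium-bearing aryl core have been examined in a functional assay on HepG2 cells (Homo sapiens) for cytotoxicity, read by MTT assay, with a stated time of 48 h; a higher number here means a weaker inhibitor, a lower number a stronger inhibitor. Compound 1 `N#C[Se]c1ccc(N2C(=O)CCC2=O)cc1` carries a selenocyanate group and a cyclic imide; in this assay compound 1 is reported as "not active" (no number reported). Compound 2 `O=C1CCCC(=O)N1c1ccc([Se][Se]c2ccc(N3C(=O)CCCC3=O)cc2)cc1` joins two such aryl units through a diselenide bridge, and in this assay compound 2 gives 35000 nM. Compound 3 `N#C[Se]c1ccc(NC(=O)CCC(=O)O)cc1` keeps the selenocyanate of compound 1 but opens the imide into an amide with a free carboxylic acid; in this assay compound 3 is recorded as "not active" (no number reported), with no numerical value given, so it stands at the inactive end of what has been measured.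

Compound 4 `N#C[Se]c1ccc(NC(=O)CCCC(=O)O)cc1` differs from compound 3 by a single change: carboxymethyl in place of carboxy on a saturated chain carbon, two bonds along the chain from a carbonyl carbon. Going by the values given here, no measured step of this kind exists among the compounds here, so the size and direction of its effect cannot be read from data. With compound 3 showing no measurable inhibition and compound 1 likewise inactive, the expectation is that compound 4 remains weak, with any shift from compound 3 not beyond the usual scatter.

On that basis the half-maximal inhibitory concentration of compound 4 in this assay is estimated at 100000 nM, within a range of 30000 nM to 400000 nM, with a considerable chance that only inactivity is reported.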

Compound 4, half-maximal inhibitory concentration: 7000 nM
Beside the measured number, compound 4's estimate is 14-fold (1.15 log units) above it, and the stated range ends above it.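

In this assay, going by these compounds alone, compound 3 has no single number, while compound 4 gives 7000 nM, so no step between compound 3 and compound 4 can be read. Nothing measured here speaks to a cause for this result. The compounds shown leave open how large the change from carboxy to carboxymethyl is, and whether it would act alike on another compound.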